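Carbamate side chain swap on the shared core, toward compound 3

The source may hold more compounds than are shown below. What is called first, only, known or untested is meant among the compounds shown, and "the series" means these compounds.

Compound 1 `O=C(Nc1nc2cc(C(=O)c3ccccc3)ccc2[nH]1)OC1COC1` in a functional assay on PC-3 cells (Homo sapiens) for cytotoxicity, read by MTT assay, with a stated time of 72 h, tested at 10 uM (on this read-out lower numbers stand for a stronger effect and higher numbers for a weaker effect at the one concentration tested), gives 65.6%. Compound 2 `CCCSc1ccc2[nH]c(NC(=O)OCCCN(C)C)nc2c1` in this assay gives 78.3%, the highest of the two numbers seen so far, with compound 1 as its nearest neighbour at a lower number beyond the scatter. Among the measured compounds shown here, no single-change step between measured compounds is available. Compound 3 `CCCSc1ccc2[nH]c(NC(=O)OC3COC3)nc2c1` differs from compound 2 by oxetan-3-yl in place of 3-(dimethylamino)propyl on an oxygen next to a carbonyl group. Compound 1 also carries oxetan-3-yl on the carbamate oxygen, but it differs from compound 3 elsewhere as well, so the two values show only that the oxetan-3-yl carbamate of compound 1 sits lower than compound 2. A small step downward is expected from compound 2 to compound 3 in this assay, a number 7.3 percentage points lower from compound 2 to compound 3 (within the scatter), possibly within the scatter. Compound 3 is estimated at 71%, within 55% to 87%.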

Compound 3, a percentage reported as activity, at one concentration (the size of the read-out at that concentration, not a potency): 84.5%
For compound 3 the middle estimate is 13.5 percentage points below the measured one; the range from low to high includes it.
By their numbers in this assay, from the lowest: compound 1; then compounds 2 and 3 (each within the scatter of the next).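

On the oxygen next to the carbonyl group, oxetan-3-yl in place of 3-(dimethylamino)propyl gives a number 6.2 percentage points higher from compound 2 to compound 3 (within the scatter) in this assay, so with propylsulfanyl on the shared core, this read-out does not separate the two side chains. Among the compounds shown here, on the aromatic carbon, with oxetan-3-yl held constant, propylsulfanyl in place of benzoyl gives a number 18.9 percentage points higher from compound 1 to compound 3 (beyond the scatter), a modest change and the only single-change step here beyond the scatter. No supporting data are available to explain either step.

On these data alone, it remains open whether a primary amine or a longer alkyl chain on the carbamate oxygen would separate from these two side chains. As far as these compounds go, it is also open whether the difference between propylsulfanyl and benzoyl would persist with 3-(dimethylamino)propyl on the carbamate, or whether a methylsulfanyl or phenoxy group on the aromatic carbon would fall nearer either value.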